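A few compounds are considered here, and "the series" means these few. Any claim that something is new, unique, unknown or untested is made for them only; others in the source may bear on it.

Measured compounds:
compound 1, `COc1ccc(-c2c(S(=O)(=O)c3ccc(F)cc3)cnc3cc(F)ccc23)cc1`, 1.77 mL/min
compound 2, `COc1ccc(-c2c(S(=O)(=O)c3ccc(F)c(F)c3)cnc3cc(F)ccc23)cc1`, 1.1 mL/min
compound 3, `O=S(=O)(c1ccc(F)c(F)c1)c1cnc2c(F)cccc2c1-c1cccc(F)c1`, 1.28 mL/min

All three were run in an ADME assay on microsomes from liver (Homo sapiens) for metabolic stability, tested at 2.5 uM; on this read-out lower numbers stand for slow clearance and higher numbers for fast clearance. Compound 2 and compound 1 differ in a single place: hydrogen in place of fluoro on an aromatic carbon. This step reads a 1.6-fold higher number from compound 2 to compound 1 (0.21 log units; within the scatter). Compound 3 carries the same 3,4-difluorophenyl as compound 2, but the difference between the cores of compound 2 and compound 3 is not broken down here; their two values stand within the usual scatter of each other, so no order between them is claimed.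

Compound 4, `O=S(=O)(c1cccc(F)c1)c1cnc2c(F)cccc2c1-c1cccc(F)c1`, is not yet measured. It differs from compound 3 by hydrogen in place of fluoro on an aromatic carbon. This is the same kind of change as that from compound 2 to compound 1, not the same change: in compound 2 the place is meta to a large group, in compound 3 it is para to a large group. Going by the values given here, the expected step from compound 3 to compound 4 in this assay is estimated at a 1.3-fold higher number from compound 3 to compound 4 (0.12 log units; within the scatter), resting on the single precedent that gave a 1.6-fold higher number from compound 2 to compound 1 (0.21 log units; within the scatter). Compound 4 is thus estimated at 1.7 mL/min, expected between 0.9 mL/min and 3.2 mL/min.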

Compound 4, intrinsic clearance in a liver preparation (reported as CLH), per the amount of preparation that the assay uses: 1.14 mL/min
Estimate against measurement, compound 4: 1.5-fold (0.17 log units) above; the measured number falls inside the stated range.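

In this assay, going from 3,4-difluorophenyl to 3-fluorophenyl gives a 1.1-fold lower number from compound 3 to compound 4 (0.05 log units; within the scatter). Set beside the earlier case, the two readings of this change do not separate: the same change on two cores in this assay, a 1.6-fold higher number (0.21 log units; within the scatter) from compound 2 to compound 1 and a 1.1-fold lower number (0.05 log units; within the scatter) from compound 3 to compound 4, 1.8-fold (0.26 log units) apart, within the scatter of two such steps. On these two cores the change therefore leaves the read-out inside the usual scatter, and the opposite directions of the two steps carry no weight; this does not show that the change is neutral on other cores, and two steps in one assay fix neither a size nor a direction for it.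

The compounds shown leave open how the read-out responds when something other than hydrogen or fluoro stands at this place on the aromatic ring, such as a nitrile, an amine or a carboxylic acid. They also leave open whether a step beyond the scatter would appear on a core carrying a longer chain in place of the aryl groups seen here.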